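A hydroxyethyl chain on the other ring nitrogen

The source may report more compounds than this note shows. Statements on the series, on what has been measured and on what is new or still open speak of the compounds shown alone.

Measured compounds:
compound 1, `Cn1c(Cc2nn(C)c(=O)c3ccccc23)nnc1SCC(=O)Nc1ccc(Cl)cc1Cl`, in an assay on 32D cells for inhibition of interleukin-15 (Mus musculus), read by resazurin assay, with stated times of 30 min and 2.5 days, in the presence of a further agent that is not named here (a lower number here means a stronger inhibitor, a higher number a weaker inhibitor), gives 22500 nM.
compound 2, `Cn1nc(Cc2nnc(SCC(=O)Nc3ccc(Cl)cc3Cl)n2CCCO)c2ccccc2c1=O`, in this assay gives only a limit, > 30000 nM.
compound 3, `Cn1nc(Cc2nnc(SCC(=O)Nc3ccc(Cl)cc3Cl)n2CCC(=O)O)c2ccccc2c1=O`, in this assay gives only a limit, > 30000 nM.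

Among the measured compounds shown here, compound 1 is the one compound with a measured number; the other two values are limits of the assay. Compound 4, `Cn1c(Cc2nn(CCCO)c(=O)c3ccccc23)nnc1SCC(=O)Nc1ccc(Cl)cc1Cl`, differs from compound 1 by 2-hydroxyethyl in place of hydrogen on a saturated chain carbon bound to an aromatic nitrogen. The same group appears in compound 2, though there it sits on the shared core's other aromatic nitrogen, and that step, an at least 1.3-fold higher number from compound 1 to compound 2 (0.12 log units; that floor lies within the scatter), moved the value to the limit. The step of an at least 1.3-fold higher number from compound 1 to compound 3 (0.12 log units; that floor lies within the scatter), with a different chain at the same place, also ended at the limit. The step that the two limits leave unreadable from compound 2 to compound 3 cannot be read, because of the limit of > 30000 nM in this assay, at which 2 of the 3 values shown sit. Compound 1 is already a weak inhibitor, so any rise in number lands close to that limit. For compound 4 a step of a 1.6-fold higher number from compound 1 to compound 4 (0.19 log units; within the scatter) toward a weaker inhibitor is therefore expected, with a real chance that only a limit is reported. The estimate for compound 4 in this assay is 35000 nM, with a range from 15000 nM to 80000 nM.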

Compound 4, half-maximal inhibitory concentration: > 30000 nM
Compound 4: a limit, no number; the forecaster's own chance of this, stated with the estimate: 60%; the middle value lies beyond the limit too.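

In this assay, compound 4 gives only a limit, > 30000 nM, and not a number. The step can be stated only as a floor, an at least 1.3-fold higher number from compound 1 to compound 4 (0.12 log units; that floor lies within the scatter), so this result does not establish a real loss of inhibition, but it does show that the 2-hydroxyethyl addition gives no measurable value at this aromatic nitrogen either. Compound 2 carries the same addition on the other aromatic nitrogen of the shared core, so the same change now ends in a limit at both places, and any comparison of compounds 2, 3 and 4 with one another cannot be read: the limit of > 30000 nM in this assay, at which 3 of the 4 values shown sit.

How far compounds 2, 3 and 4 lie beyond that limit remains unknown, so the compounds shown cannot say which place tolerates the 3-hydroxypropyl chain better, if either does. Also open, going by these compounds, is whether an ethyl group, or a propyl chain ending in an amine or a methoxy group, in place of the methyl on either nitrogen would give a value that can be measured.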